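Diethylamino in place of propyl on the carbonyl carbon

The compounds below may be only part of what the source reports. "The series", "measured", "known", "first", "only" and "open" are said of these compounds alone.

Measured so far in an assay on membranes from HeLa cells for displacement of a labelled ligand from adenosine receptor A3 (Homo sapiens), read by scintillation counting, with a stated time of 180 min, tested at 1 uM; on this read-out higher numbers stand for more inhibition at the one concentration tested (going by the name of the read-out) and lower numbers for less inhibition:
compound 1 `CCCC(=O)C1=C(C)NC(=O)NC1c1ccoc1` gives 2%
compound 2 `CCCC(=O)C1=C(C)NC(=O)NC1c1cccs1` gives 2%
compound 3 `CCCC(=O)C1=C(C)NC(=O)NC1c1ccsc1` gives 1%

On the bare numbers compound 3 sits lowest of the three, but its gaps to compound 1 and to compound 2 are within the scatter, so the three compounds read alike. The recorded steps, no change at the digits printed from compound 1 to compound 2 (within the scatter), a number 1 percentage points lower from compound 1 to compound 3 (within the scatter) and a number 1 percentage points lower from compound 2 to compound 3 (within the scatter), all exchange the aryl group on the saturated ring carbon, and none moves the read-out beyond the scatter. Compound 4 `CCN(CC)C(=O)C1=C(C)NC(=O)NC1c1ccsc1` differs from compound 3 at another place: diethylamino in place of propyl on a carbonyl carbon. Among the measured compounds shown here, no measured step tests a change on the carbonyl carbon, so there is nothing to carry over directly; all three numbers lie near zero and the expectation is no step beyond the scatter, a number 1 percentage points higher from compound 3 to compound 4 (within the scatter). Compound 4 is therefore estimated to give 2% in this assay, with an expected range from -5% to 10%.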

Compound 4, a percentage reported as inhibition, at one concentration (the size of the read-out at that concentration, not a potency): 35%
Compound 4: middle estimate off by 33 percentage points, on the low side, and the stated range ends below it.
By their numbers in this assay, from the lowest: compounds 3, 1 and 2 (each within the scatter of the next); then compound 4.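

Read in this assay the carbonyl carbon is the first place in this series where a single change moves the numbers beyond the scatter: diethylamino in place of propyl gives a number 34 percentage points higher from compound 3 to compound 4 (beyond the scatter) and so separates compound 4 from the other compounds. The aryl exchanges among compound 1, compound 2 and compound 3 gave no such separation. Nothing available explains this rise.

On these data alone, whether it follows the nitrogen or the chain size stays open: dimethylamino, piperidine or a pentyl chain on the carbonyl carbon would separate the two. Also open, as far as these compounds go, is whether furan-3-yl and thiophen-2-yl still read alike with diethylamino in place.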